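Swapping a phenyl ester for a dimethylamide

This account rests on a few compounds, and the source may have more. Where it says the series, first, only, none or still open, it means among the compounds named here.

Measured compounds:
compound 1, `CC(/C=C/CC(C)CCCC(C)C)=C\C(=O)Oc1ccccc1`, 7.67
compound 2, `COC(C)(C)CCCC(C)C/C=C/C(C)=C/C(=O)OC(C)(C)C`, 6.36

Of the compounds shown here, two have been measured in a physicochemical assay for lipophilicity; on this read-out lower numbers stand for lower lipophilicity and higher numbers for higher lipophilicity. Compound 1 gives 7.67, and compound 2 gives 6.36. Of the two numbers, compound 1 stands highest, and the gap to compound 2 is wide enough to lie beyond the usual scatter of repeated measurements. The two compounds differ in several places at once, so no single structural change can be read from their two values.

Compound 3, `CC(/C=C/CC(C)CCCC(C)C)=C\C(=O)N(C)C`, has not yet been measured in this assay. It differs from compound 1 in one place only: dimethylamino in place of phenoxy on a carbonyl carbon. The phenoxy group that leaves carries a six-membered aromatic ring and an oxygen, while the dimethylamino group that enters is small and brings a nitrogen. Among the measured compounds shown here, no measured pair shows this particular change here, so the direction and size must be guessed. A clear drop beyond the scatter is expected. Compound 3 is expected to give 5.7, with a range from 5 to 6.4. The step of a number 1.97 log units lower from compound 1 to compound 3 (beyond the scatter) is the change expected from this replacement.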

Compound 3, partition coefficient: 4.94
Compound 3: middle estimate off by 0.76 log units, on the high side; the whole stated range lies above it.
By their numbers in this assay, from the lowest: compound 3; then compound 2; then compound 1.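

Dimethylamino in place of phenoxy on a carbonyl carbon gives, in this assay, a number 2.73 log units lower from compound 1 to compound 3 (beyond the scatter). Among the compounds shown here, this is the first comparison here with only one place changed, so the step can be tied to this replacement at this position on an otherwise shared core, which the two earlier compounds could not show. The replacement changes several things at once, removing the aromatic ring, exchanging oxygen for nitrogen and reducing the number of heavy atoms, and nothing available here explains the size of the step or divides it among those changes.

The compounds shown leave open which part of the replacement matters most: an anilino group on the same carbonyl carbon would keep an aromatic ring while bringing a nitrogen, whereas a methoxy group would lose the ring but keep the oxygen. A diethylamino group or a carboxylic acid at this place would show how far the number moves with other groups, and the same replacement on a different chain would test whether the step carries over.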